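Swapping the Ring Substituent in a Small Ester Series

The source may hold more compounds than are shown below. What is called first, only, known or untested is meant among the compounds shown, and "the series" means these compounds.

Three esters sharing one core have been tested in an assay on isolated protein for inhibition of matrix metalloproteinase-9 (Homo sapiens); on this read-out higher numbers stand for weaker inhibition and lower numbers for stronger inhibition. Compound 1 `O=C(OCc1ccc(F)cc1)c1cccc(=O)[nH]1` carries a fluoro group on its benzyl ring and gives 3000 nM. Compound 2 `O=C(OCc1ccc(C(F)(F)F)cc1)c1cccc(=O)[nH]1` carries a trifluoromethyl group in that position and gives 101000 nM. Compound 3 `O=C(OCc1ccc(Cl)cc1)c1cccc(=O)[nH]1` carries a chloro group and gives 68000 nM. Among these three numbers compound 3 holds the second highest; its value and that of compound 2 lie within the usual scatter of each other, while compound 1 sits far lower.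

Compound 4 `Cc1ccc(COC(=O)c2cccc(=O)[nH]2)cc1` has not been measured. It differs from compound 3 in a single point: methyl in place of chloro on an aromatic carbon. The measured steps offer only a loose guide. Exchanging fluoro for trifluoromethyl gave a 34-fold higher number from compound 1 to compound 2 (1.53 log units; beyond the scatter), and exchanging fluoro for chloro gave a 23-fold higher number from compound 1 to compound 3 (1.36 log units; beyond the scatter); between chloro and trifluoromethyl the difference was a 1.5-fold lower number from compound 2 to compound 3 (0.17 log units; within the scatter). Going by the values given here, the numbers for chloro and trifluoromethyl thus lie close together while fluoro stands apart, and methyl has no direct precedent in this set. The step from compound 3 to compound 4 is therefore expected to be modest, a 1.1-fold lower number from compound 3 to compound 4 (0.05 log units; within the scatter), with the direction uncertain. Compound 4 is estimated at 60000 nM, with a likely range from 10000 nM to 200000 nM.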

Compound 4, half-maximal inhibitory concentration: 68000 nM
Compound 4: the middle estimate sits 1.1-fold (0.05 log units) below what was measured, and the stated range covers the measured number.
By their numbers in this assay, from the lowest: compound 1; then compounds 3, 4 and 2 (each within the scatter of the next).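

With methyl in this place on the benzyl ring, this assay shows no change at the digits printed from compound 3 to compound 4 (within the scatter) and also a 1.5-fold lower number from compound 2 to compound 4 (0.17 log units; within the scatter), so compounds 2, 3 and 4 form one cluster. Methyl carries no halogen, so the cluster is not confined to groups that contain one: a single carbon in place of a single chlorine leaves the number where it was, and trifluoromethyl, which contains fluorine, also sits in this cluster. Fluoro is now the only one of the four groups that goes against this cluster, as the large step shows, a 23-fold higher number from compound 1 to compound 4 (1.36 log units; beyond the scatter), and no measurement here explains why it stands apart.

On these data alone, the low number rests on compound 1 alone, so it remains open whether fluoro is a lone exception or one of several groups that give a much lower number here. Plain hydrogen, a hydroxyl, an amine or a carboxylic acid in this place could show on which side of that divide other groups fall, and whether anything on this ring can go lower still.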